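Replacing a pyrazolyl ring with ethoxy on the shared core

The source may report more compounds than this note shows. Statements on the series, on what has been measured and on what is new or still open speak of the compounds shown alone.

Measured compounds:
- Compound 1 `CCc1ccc(Cl)c(C(=O)NC(=O)Nc2nc3ccc(S(=O)(=O)CCCN4CCN(C)CC4)cc3s2)c1`: 0.078 nM
- Compound 2 `Cc1ccn(-c2ccc(Cl)c(C(=O)NC(=O)Nc3nc4ccc(S(=O)(=O)CCCN5CCN(C)CC5)cc4s3)c2)n1`: 0.53 nM

Both were tested in an assay on HEK293 cells for displacement of a labelled ligand from growth hormone secretagogue receptor type 1 (Homo sapiens), with a stated time of 60 min; on this read-out lower numbers stand for stronger inhibition and higher numbers for weaker inhibition. Compound 1 carries an ethyl group on its aromatic ring; compound 2 carries a 3-methyl-1H-pyrazol-1-yl group there instead, and the step of a 6.8-fold higher number from compound 1 to compound 2 (0.83 log units; beyond the scatter) shows that this swap weakened binding. Of the two numbers, compound 2 has the higher one.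

Compound 3 `CCOc1ccc(Cl)c(C(=O)NC(=O)Nc2nc3ccc(S(=O)(=O)CCCN4CCN(C)CC4)cc3s2)c1` is the next variation. Its change from compound 2 is ethoxy in place of 3-methyl-1H-pyrazol-1-yl on an aromatic carbon, on an aromatic carbon of a six-membered aromatic ring of carbon only, meta to a large group and para to a chloro group. Within the data shown here, the only measured step that bears on this position, from compound 1 to compound 2, shows that a small group there gave the stronger number, while the larger pyrazolyl ring cost potency. Ethoxy is small, like ethyl, so compound 3 is expected to move back toward compound 1, an expected step of a 4.4-fold lower number from compound 2 to compound 3 (0.65 log units; beyond the scatter). The estimate for compound 3 in this assay is 0.12 nM, within 0.04 nM to 0.4 nM.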

Compound 3, half-maximal inhibitory concentration in the growth hormone secretagogue receptor type 1 assay: 0.31 nM
Compound 3: middle estimate off by 2.6-fold (0.41 log units), on the low side; the range from low to high includes it.
By their numbers in the growth hormone secretagogue receptor type 1 assay, from the lowest: compound 1; then compounds 3 and 2 (each within the scatter of the next).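

In the growth hormone secretagogue receptor type 1 assay, the step of a 1.7-fold lower number from compound 2 to compound 3 (0.23 log units; within the scatter) leaves ethoxy and 3-methyl-1H-pyrazol-1-yl indistinguishable, so losing the ring on this aromatic carbon does not by itself bring the number back toward compound 1 at 0.078 nM. Also in the growth hormone secretagogue receptor type 1 assay, the step of a 4.0-fold higher number from compound 1 to compound 3 (0.60 log units; beyond the scatter) separates ethoxy from ethyl, so two small groups without a ring are not interchangeable at this position. In a physicochemical assay for lipophilicity (a lower number here means a more polar compound, a higher number a more lipophilic compound), compound 2 gives 2.6 and compound 3 gives 2.4, and the step of a number 0.20 log units lower from compound 2 to compound 3 (within the scatter) shows that the two cannot be told apart on lipophilicity either.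

Going by these compounds, whether a methoxy group, a propyl chain or an amine on this carbon would give a number closer to that of ethyl or that of ethoxy remains open. Nothing available here explains why ethyl and ethoxy differ.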